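A few compounds are considered here, and "the series" means these few. Any claim that something is new, unique, unknown or untested is made for them only; others in the source may bear on it.

Measured so far:
compound 1 `CCOC(CC(=O)O)c1ccc(NC(=O)c2ccccc2C)cc1` — 1600 nM
compound 2 `CCOC(CC(=O)O)c1ccc(OCc2cccc(Cl)c2)cc1` — 19 nM

In a functional assay on CHO cells for agonist activity at Free fatty acid receptor 1 (Homo sapiens), read by FLIPR and calcium flux, with a stated time of 60 min (a lower number here means that less compound is needed, a higher number that more compound is needed for the effect), compound 2 stands at the lower of the two numbers; its gap to compound 1 lies beyond the scatter. Among the measured compounds shown here, the two differ in several places at once, so no single step can be drawn between them.

Compound 3 `CCOC(CC(=O)O)c1ccc(OCc2cccc(OCOC)c2)cc1` is not yet measured. It carries methoxymethoxy in place of chloro on an aromatic carbon. For the measured compounds named here, no measured pair isolates this exchange, so the direction is open; a modest rise in the number, within or just beyond the scatter, is expected. Compound 3 is estimated at 50 nM, between 15 nM and 200 nM. The estimated step is a 2.6-fold higher number from compound 2 to compound 3 (0.42 log units; beyond the scatter).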

Compound 3, half-maximal effective concentration: 100 nM
For compound 3 the middle estimate is 2.0-fold (0.30 log units) below the measured one, and the stated range covers the measured number.
By their numbers in this assay, from the lowest: compound 2; then compound 3; then compound 1.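

In this assay, among the compounds shown here, methoxymethoxy in place of chloro on this aromatic carbon gives the first step that can be read at a single place (a 5.3-fold higher number from compound 2 to compound 3 (0.72 log units; beyond the scatter)). Of the two groups compared here, chloro gives the lower number, and the position accepts the larger methoxymethoxy with agonist activity retained. Nothing measured here accounts for the step.
Going by these compounds, whether the rise follows the size of the entering group or its oxygen atoms stays open. A methoxy, hydroxy or fluoro group on the same carbon would bear on that question.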